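Swapping a silicon group for diisopropylcarbamoyl

A few compounds are considered here, and "the series" means these few. Any claim that something is new, unique, unknown or untested is made for them only; others in the source may bear on it.

Values in a functional assay on MCF7 cells (Homo sapiens) for antiproliferative activity, read by MTT assay, with a stated time of 48 h; a higher number here means a weaker inhibitor, a lower number a stronger inhibitor:
- Compound 1 `CCN(CC)C/C1=C/C[C@](C)(CCC=C(C)C)/C=C/[C@@H](OC(=O)C=C(C)C)[C@](C)(O)/C=C/C1=O` gives 130 nM
- Compound 2 `CC[Si](CC)(CC)C/C1=C/C[C@](C)(CCC=C(C)C)/C=C/[C@@H](OC(=O)C=C(C)C)[C@](C)(O)/C=C/C1=O` gives 3150 nM
- Compound 3 `CC(C)=CCC[C@]1(C)/C=C/[C@@H](OC(=O)C=C(C)C)[C@](C)(O)/C=C/C(=O)/C(C[Si](C)(C)C(C)(C)C)=C\C1` gives 6040 nM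

Compound 3 sits at the weak end of this small set, alongside the other silicon compound. The gap between those two is small: a 1.9-fold higher number from compound 2 to compound 3 (0.28 log units; within the scatter). The change from the nitrogen group to a silicon group was large both times: a 24-fold higher number from compound 1 to compound 2 (1.38 log units; beyond the scatter) and a 46-fold higher number from compound 1 to compound 3 (1.67 log units; beyond the scatter).

Compound 4 `CC(C)=CCC[C@]1(C)/C=C/[C@@H](OC(=O)C=C(C)C)[C@](C)(O)/C=C/C(=O)/C(C(=O)N(C(C)C)C(C)C)=C\C1` gives up the silicon group of compound 3 for diisopropylcarbamoyl on a double-bonded ring carbon: a group of 9 heavy atoms (7 carbon, 1 nitrogen, 1 oxygen; no ring) in place of a group of 8 heavy atoms (7 carbon, 1 silicon; no ring), on a double-bonded ring carbon. Going by the values given here, no measured compound carries this group, so no measured step covers it directly. Compound 4 does bring back nitrogen, as found in compound 1 at 130 nM, but the two groups differ, so only a partial recovery is expected. In this assay the expected step is a modest one toward a lower number: a 2.0-fold lower number from compound 3 to compound 4 (0.30 log units; within the scatter). The estimate for compound 4 is 3000 nM, with an expected range of 800 nM to 10000 nM.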

Compound 4, half-maximal inhibitory concentration: 17200 nM
Beside the measured number, compound 4's estimate is 5.7-fold (0.76 log units) below it; the whole stated range lies below it.
By their numbers in this assay, from the lowest: compound 1; then compounds 2 and 3 (each within the scatter of the next); then compound 4.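

The new group does not recover what the nitrogen of compound 1 seemed to offer, so a nitrogen atom alone does not bring back activity at this double-bonded ring carbon. Diisopropylcarbamoyl is in fact worse than either silicon group, with a 2.8-fold higher number from compound 3 to compound 4 (0.45 log units; beyond the scatter) and a 5.5-fold higher number from compound 2 to compound 4 (0.74 log units; beyond the scatter), and it falls far short of (diethylamino)methyl, with a 130-fold higher number from compound 1 to compound 4 (2.12 log units; beyond the scatter) in this assay. Nothing measured here explains why these groups rank in this order.

Diisopropylcarbamoyl and (diethylamino)methyl differ both in the carbonyl and in the isopropyl or ethyl groups on nitrogen, so it remains open which of these accounts for the gap. A (diisopropylamino)methyl group or a diethylcarbamoyl group on the same carbon would separate the two.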